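Urea to amide on the shared core: compound 4

The compounds below may be only part of what the source reports. "The series", "measured", "known", "first", "only" and "open" are said of these compounds alone.

Within a functional assay on SK-OV-3 cells (Homo sapiens) for inhibition, read by sulforhodamine B assay, with a stated time of 48 h, tested at 1 uM (a higher number here means a weaker effect of the compound at the concentration tested, a lower number a stronger effect), three compounds are measured. Compound 1 `O=C(Nc1cccc(-n2cc(-c3ccncc3)c(-c3cc(O)cc(Cl)c3)n2)c1)Nc1ccc(Cl)c(Cl)c1` gives 110% and compound 3 `COc1cc(Cl)cc(-c2nn(-c3cccc(NC(=O)Nc4ccc(Cl)c(Cl)c4)c3)cc2-c2ccncc2)c1` gives 100%; the step of a number 10 percentage points lower from compound 1 to compound 3 (within the scatter) carries methyl in place of hydrogen on an oxygen on an aromatic ring. Compound 2 `COc1cc(Cl)cc(-c2nn(-c3cccc(NC(=O)Nc4cc(C(F)(F)F)cc(C(F)(F)F)c4)c3)cc2-c2ccncc2)c1` gives 43%. Compound 3 thus stands second highest of the three, close to compound 1 and far from compound 2. Compound 4 `COc1cc(Cl)cc(-c2nn(-c3cccc(NC(=O)c4cccc(C(F)(F)F)c4)c3)cc2-c2ccncc2)c1` brings (3-(trifluoromethyl)phenyl in place of (3,4-dichlorophenyl)amino on a carbonyl carbon). Going by the values given here, no measured step touches this change: the only measured step is within the scatter, and compound 2 differs from compound 3 elsewhere on the shared core. The step of a number 15 percentage points lower from compound 3 to compound 4 (beyond the scatter) is therefore expected to be small and of uncertain direction. For compound 4 the estimate is 85%, in the range 45% to 115%.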

Compound 4, a percentage reported as activity, at one concentration (the size of the read-out at that concentration, not a potency): 99%
Compound 4: middle estimate off by 14 percentage points, on the low side; measured number inside the range.
By their numbers in this assay, from the lowest: compound 2; then compounds 4, 3 and 1 (each within the scatter of the next, the first and the last beyond it).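

In this assay, replacing (3,4-dichlorophenyl)amino with 3-(trifluoromethyl)phenyl on a carbonyl carbon turns the urea into an amide and gives a number 1 percentage points lower from compound 3 to compound 4 (within the scatter). This position therefore accepts the urea-to-amide change without a shift beyond the scatter, although the comparison is made only where compound 3 gives 100% and compound 4 gives 99%, both showing little effect at the tested concentration. No available evidence bears on this result.

From the compounds shown here alone, it remains open whether a morpholine or a carboxylic acid in place of 3-(trifluoromethyl)phenyl on the carbonyl carbon would move this read-out.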